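This account rests on a few compounds, and the source may have more. Where it says the series, first, only, none or still open, it means among the compounds named here.

Measured compounds in an ADME assay on PANC-1 cells (Homo sapiens) for cytotoxicity, read by MTT assay, with a stated time of 48 h; a higher number here means a weaker inhibitor of growth, a lower number a stronger inhibitor of growth:
compound 1 `Cc1ccc(/C=C\C(=O)N2N=C(c3ccncc3)OC2c2c[nH]c3ccccc23)cc1` gives > 30 ug/mL, a limit of the assay.
compound 2 `O=C(/C=C\c1ccccc1F)N1N=C(c2ccncc2)OC1c1c[nH]c2ccccc12` gives > 30 ug/mL, a limit of the assay.
compound 3 `O=C(/C=C\c1cccc(F)c1)N1N=C(c2ccncc2)OC1c1c[nH]c2ccccc12` gives > 30 ug/mL, a limit of the assay.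

Compound 1 thus stands only at a limit in this assay, and the two further values are limits as well (the limit of > 30 ug/mL in this assay, at which 3 of the 3 values shown sit). Compound 4 `O=C(/C=C\c1cccc(Cl)c1Cl)N1N=C(c2ccncc2)OC1c1c[nH]c2ccccc12` differs from compound 1 in one place: 2,3-dichlorophenyl in place of 4-methylphenyl on a double-bonded chain carbon bound to a double-bonded chain carbon. The measured steps touching this place are a step that the two limits leave unreadable from compound 1 to compound 2, a step that the two limits leave unreadable from compound 1 to compound 3 and a step that the two limits leave unreadable from compound 2 to compound 3, none of which has a readable size. With all three values at a limit, no step beyond the scatter is expected here, and the most likely outcome for compound 4 is again a limit. Compound 4 is estimated at 35 ug/mL, range 12 ug/mL to 100 ug/mL. The expected step is therefore a step that the limit leaves unreadable from compound 1 to compound 4.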

Compound 4, concentration for 50% growth inhibition: > 30 ug/mL
Compound 4 gave a limit, no number; the forecaster's own chance of this, stated with the estimate: 70%; the middle value lies beyond the limit too.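

Compound 4 sits at a limit in this assay, as do compound 1, compound 2 and compound 3, so none of the steps among them can be read: the limit of > 30 ug/mL in this assay, at which 4 of the 4 values shown sit.

The compounds shown leave open whether 4-methylphenyl, 2-fluorophenyl, 3-fluorophenyl and 2,3-dichlorophenyl differ at all in growth inhibition.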